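Swapping the Side-Chain Pyrrolidine for a Methoxy Group

This account rests on a few compounds, and the source may have more. Where it says the series, first, only, none or still open, it means among the compounds named here.

Compound 1, `Cn1ncc(Cl)c1-c1cc(C(=O)N[C@@H]2CN[C@H](CCN3CCCCC3)C[C@H]2c2ccc(Cl)c(Cl)c2)oc1Cl`: 5.65 nM
Compound 2, `Cn1ncc(Cl)c1-c1cc(C(=O)N[C@@H]2CN[C@H](CCN3CCCC3)C[C@H]2c2ccc(Cl)c(Cl)c2)oc1Cl`: 6.41 nM

In an assay for inhibition of RAC-alpha serine/threonine-protein kinase (Homo sapiens), read by HTRF, with a stated time of 1 h (a higher number here means a weaker inhibitor, a lower number a stronger inhibitor), compound 2 gives the higher of the two numbers, but its gap to compound 1 is within the scatter. Compound 3, `COCC[C@@H]1C[C@@H](c2ccc(Cl)c(Cl)c2)[C@H](NC(=O)c2cc(-c3c(Cl)cnn3C)c(Cl)o2)CN1`, is not yet measured. It differs from compound 2 by methoxy in place of pyrrolidin-1-yl on a saturated chain carbon, two bonds along the chain from a saturated ring carbon. Among the compounds with values here, the one measured step at this position, a 1.1-fold higher number from compound 1 to compound 2 (0.05 log units; within the scatter), exchanged one ring for another and changed little. Within the data shown here, no measured step removes the ring altogether, so the expectation is uncertain; a modest rise in the number is expected, a 1.9-fold higher number from compound 2 to compound 3 (0.27 log units; within the scatter). Compound 3 is estimated at 12 nM, in a range from 4 nM to 40 nM.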

Compound 3, half-maximal inhibitory concentration: 7.01 nM
For compound 3 the middle estimate is 1.7-fold (0.23 log units) above the measured one, within the range that was stated.
By their numbers in this assay, from the lowest: compounds 1, 2 and 3 (each within the scatter of the next).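

In this assay the ring at the end of the side chain and its nitrogen can both be replaced without a readable change: methoxy gives a 1.1-fold higher number from compound 2 to compound 3 (0.04 log units; within the scatter) and a 1.2-fold higher number from compound 1 to compound 3 (0.09 log units; within the scatter) here. The earlier step only exchanged one ring for another, whereas these steps show that compound 3 cannot be told apart from compound 1 or compound 2 with no ring at this position at all. Nothing available explains this result. As far as these compounds go, whether a hydroxyl group, a primary amine, a carboxylic acid or a longer chain would also leave the number within the scatter stays open.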